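The source may hold more compounds than are shown below. What is called first, only, known or untested is meant among the compounds shown, and "the series" means these compounds.

Compound 2 `N#Cc1cccc(Nc2cc(C3CC3)c(C(=O)NCC3CCOCC3)cn2)c1` is measured in a physicochemical assay for solubility, at pH 7.4 (on this read-out higher numbers stand for higher solubility and lower numbers for lower solubility), where compound 2 gives 4 ug/mL. Compound 1 `O=C(NCC1CCOCC1)c1cnc(Nc2cc(Cl)cc(Cl)c2)cc1C1CC1` gives 7 ug/mL, a number within the scatter of compound 2, so the two cannot be ranked. Compound 3 `CC(C)(C)c1cc(Nc2ccc(Cl)cc2Cl)ncc1C(=O)NCC1CCOCC1` gives 23 ug/mL, a number beyond the scatter above both; compound 3 differs from compound 2 in two places, so no single step accounts for it. Compound 4 `O=C(NCC1CCOCC1)c1cnc(Nc2cccc(OC(F)(F)F)c2)cc1C1CC1` differs from compound 2 by trifluoromethoxy in place of cyano on an aromatic carbon. For the measured compounds named here, the one step that bears on this, a change of the same kind on the same ring, is a 1.8-fold lower number from compound 1 to compound 2 (0.24 log units; within the scatter). On that basis the expected step is a 1.5-fold higher number from compound 2 to compound 4 (0.18 log units; within the scatter), with no change beyond the scatter. Compound 4 is therefore estimated at 6 ug/mL, ranging from 2 ug/mL to 18 ug/mL.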

Compound 4, solubility: < 1 ug/mL
Compound 4 ended at the assay's limit; the forecaster's own chance of this, stated with the estimate: 5%; middle value at least 6.0-fold (0.77 log units) from the limit.
By their numbers in this assay, from the lowest: compounds 2 and 1 (each within the scatter of the next); then compound 3. At a limit, below all of these: compound 4.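

In this assay trifluoromethoxy in place of cyano on this aromatic carbon gives an at least 4.0-fold lower number from compound 2 to compound 4 (0.60 log units; beyond the scatter) and so moves the number beyond the scatter. For the compounds shown here, the earlier change on this ring (a 1.8-fold lower number from compound 1 to compound 2 (0.24 log units; within the scatter)) stayed within the scatter, so this is the first step here that can be read as a real drop. Compound 4 stands at a limit of the assay and not at a number: the limit of < 1 ug/mL in this assay, at which 1 of the 4 values shown sits.

From the compounds shown here alone, how far compound 4 truly lies under that limit stays open. Also open, going by these compounds, is how methoxy, or an amine, would compare with cyano on this same carbon.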